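This account rests on a few compounds, and the source may have more. Where it says the series, first, only, none or still open, it means among the compounds named here.

Measured compounds:
compound 1, `O=C(N[C@@H]1CCCC[C@H]1O)c1cnc(OC2CCCCC2)c(-c2ccc(Cl)cc2)c1`: 0.662 mL/min/kg
compound 2, `O=C(N[C@@H]1CCCC[C@H]1O)c1cnc(OCC(F)(F)F)c(-c2ccc(Cl)cc2)c1`: 0.023 mL/min/kg
compound 3, `Cc1cc(COc2ncc(C(=O)N[C@@H]3CCCC[C@H]3O)cc2-c2ccc(Cl)cc2)on1`: 0.151 mL/min/kg

All three were tested in an ADME assay (liver) for pharmacokinetics, with Liver microsome (Rattus norvegicus) as the target, read by LC-MS, using microsomes, tested at 2 uM; on this read-out higher numbers stand for fast clearance and lower numbers for slow clearance. Among these three numbers compound 1 stands highest, and both other compounds lie beyond the scatter from it: a 29-fold lower number from compound 1 to compound 2 (1.46 log units; beyond the scatter), and a 4.4-fold lower number from compound 1 to compound 3 (0.64 log units; beyond the scatter). Compound 2 and compound 3 differ from each other only in the group carried on the same oxygen, and here the ordering is a 6.6-fold higher number from compound 2 to compound 3 (0.82 log units; beyond the scatter).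

The new compound 4, `O=C(N[C@@H]1CCCC[C@H]1O)c1cnc(OCc2ccncc2)c(-c2ccc(Cl)cc2)c1`, changes compound 1 in that same place: (pyridin-4-yl)methyl in place of cyclohexyl on an oxygen on an aromatic ring. The two earlier exchanges of the cyclohexyl on this oxygen bear directly on this step, and each gave a lower number in this assay, one large and one modest. The expected step is therefore downward, of a size between those two: a 5.5-fold lower number from compound 1 to compound 4 (0.74 log units; beyond the scatter). For compound 4 a clearance of 0.12 mL/min/kg is estimated, with a range from 0.03 mL/min/kg to 0.45 mL/min/kg.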

Compound 4, clearance: 0.118 mL/min/kg
Estimate against measurement, compound 4: 1.0-fold (0.01 log units) above; low and high end bracket the measured number.
By their numbers in this assay, from the lowest: compound 2; then compounds 4 and 3 (each within the scatter of the next); then compound 1.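

In this assay, (pyridin-4-yl)methyl on this oxygen gives a 5.6-fold lower number from compound 1 to compound 4 (0.75 log units; beyond the scatter), so a group with a six-membered aromatic ring holding one nitrogen also falls short of the cyclohexyl number. On the saturated chain carbon, pyridin-4-yl and 3-methyl-1,2-oxazol-5-yl cannot be told apart, at a 1.3-fold lower number from compound 3 to compound 4 (0.11 log units; within the scatter), whereas pyridin-4-yl in place of trifluoromethyl gives a 5.1-fold higher number from compound 2 to compound 4 (0.71 log units; beyond the scatter), so the two aromatic rings sit together and trifluoromethyl stays apart from both. Nothing available here explains why these groups differ.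

Still open, going by these compounds, is whether the ring nitrogen matters at all, a question that phenyl on the same chain carbon would address. A longer chain carrying the pyridin-4-yl would show whether the length of the link to the ring changes the number.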